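This account rests on a few compounds, and the source may have more. Where it says the series, first, only, none or still open, it means among the compounds named here.

Compound 1 `CCCCCCCCS(=O)(=O)Nc1cc(-c2ccccc2OC)ccc1C(=O)O`: 16100 nM
Compound 2 `CCCCCCCCS(=O)(=O)Nc1ccc(-c2ccc(-c3ccccc3)cc2)cc1C(=O)O`: 29100 nM
Compound 3 `CCCCCCCCS(=O)(=O)Nc1ccc(-c2ccc(OC)cc2)cc1C(=O)O`: 19500 nM

In an assay on mitochondria (strain BALB/c) for inhibition of glycerol-3-phosphate acyltransferase 1, mitochondrial (Mus musculus), read by scintillation counting, with a stated time of 10 min (on this read-out higher numbers stand for weaker inhibition and lower numbers for stronger inhibition), compound 3 gives 19500 nM, and this number lies within the usual scatter of both compound 1 and compound 2, so no order among the three can be read from it. Compound 4 `CCCCCCCCS(=O)(=O)Nc1ccc(/C=C/c2ccc(OC)cc2)cc1C(=O)O` has not been measured. It differs from compound 3 by 2-(4-methoxyphenyl)ethenyl in place of 4-methoxyphenyl on an aromatic carbon. Among the measured compounds shown here, the only measured step at the same aromatic carbon, a 1.5-fold lower number from compound 2 to compound 3 (0.17 log units; within the scatter), stayed within the scatter, and no measured step tests a change of this kind, so no shift beyond the scatter is expected in this assay. For compound 4 the expected step is no change at the digits printed from compound 3 to compound 4 (within the scatter). Compound 4 is therefore estimated at 19500 nM, with a range from 8000 nM to 45000 nM.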

Compound 4, half-maximal inhibitory concentration: 37100 nM
For compound 4 the middle estimate is 1.9-fold (0.28 log units) below the measured one; the measured number falls inside the stated range.
By their numbers in this assay, from the lowest: compounds 1, 3, 2 and 4 (each within the scatter of the next, the first and the last beyond it).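

In this assay, placing 2-(4-methoxyphenyl)ethenyl on this aromatic carbon in place of 4-methoxyphenyl gives a 1.9-fold higher number from compound 3 to compound 4 (0.28 log units; within the scatter) in this single comparison. This is the second change at this carbon to stay within the scatter, and the first to bring in a double bond outside aromatic rings. Nothing available explains the result. The compounds shown leave open whether an amine or a carboxylic acid at this aromatic carbon would move the number beyond the scatter. They also leave open what an amide in place of the ethenyl link would do.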